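Cytotoxicity in HEp-2 Cells Along an Amide Chain Extension

The source may hold more compounds than are shown below. What is called first, only, known or untested is meant among the compounds shown, and "the series" means these compounds.

Compound 1 `Cc1ccc2nc(N3CCCc4ccc(F)cc4C3)cc(NCC3(N)COC3)c2c1`: > 100000 nM
Compound 2 `Cc1ccc2nc(N3CCCc4ccc(F)cc4C3)cc(NCC(N)=O)c2c1`: 22000 nM

In an ADME assay on HEp-2 cells (Homo sapiens) for cytotoxicity, read by CCK-8 assay, with a stated time of 5 days (a lower number here means that less compound is tolerated, a higher number that more compound is tolerated), compound 1 gives > 100000 nM, which is a limit of the assay and not a number. Compound 2 gives 22000 nM in this assay. The step between them, an at least 4.5-fold lower number from compound 1 to compound 2 (0.65 log units; beyond the scatter), is the only measured step, and compound 2 therefore holds the only number shown, the other value being a limit (the limit of > 100000 nM in this assay, at which 1 of the 2 values shown sits).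

Compound 3 `CC(=O)NCCNc1cc(N2CCCc3ccc(F)cc3C2)nc2ccc(C)cc12` carries acetamidomethyl in place of carbamoyl on a saturated chain carbon bound to a nitrogen on an aromatic ring. For the measured compounds named here, the one measured step does bear on it, but only loosely: it replaced 3-aminooxetan-3-yl with carbamoyl, whereas here the amide is kept and the chain between the anilinic nitrogen and the amide is lengthened, from carbamoylmethyl to 2-acetamidoethyl. Going by the values given here, no measured step tells how this assay answers such a lengthening. Compound 3 is therefore expected to stay close to compound 2, with a step of a 1.1-fold higher number from compound 2 to compound 3 (0.06 log units; within the scatter) that is not expected to exceed the scatter. The estimate for compound 3 in this assay is 25000 nM, between 9000 nM and 80000 nM.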

Compound 3, half-maximal cytotoxic concentration: 66000 nM
Beside the measured number, compound 3's estimate is 2.6-fold (0.42 log units) below it, and the stated range covers the measured number.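

In this assay, the change at this position, on a saturated chain carbon bound to a nitrogen on an aromatic ring, gives a 3.0-fold higher number from compound 2 to compound 3 (0.48 log units; beyond the scatter), so going from carbamoylmethyl to 2-acetamidoethyl registers even though the hydrogen-bond donor and acceptor counts stay the same. The earlier step, which exchanged 3-aminooxetan-3-yl for carbamoyl, could not show that this position responds to a change that keeps an amide and adds only chain carbons. Replacing 3-aminooxetan-3-yl with acetamidomethyl instead gives an at least 1.5-fold lower number from compound 1 to compound 3 (0.18 log units; that floor lies within the scatter), and the value of compound 1 is a limit of the assay and not a number, so this step sets only a floor: the limit of > 100000 nM in this assay, at which 1 of the 3 values shown sits.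

The compounds shown leave open whether the higher number belongs to the added chain length or to the acetamide end, since both change together in the one step from carbamoyl to acetamidomethyl. They also leave open where a still longer chain ending in the same acetamide, or a primary amine or a carboxylic acid on this chain, would stand in this assay.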